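Fluoro for methyl on the urea phenyl of compound 3

The source may report more compounds than this note shows. Statements on the series, on what has been measured and on what is new or still open speak of the compounds shown alone.

The series shares a core carrying a urea, tested in a functional assay on cells (T-cell, Mus musculus) for inhibition; a higher number here means a weaker inhibitor, a lower number a stronger inhibitor. In this assay compound 1 `O=C(Nc1ccccc1)Nc1ccc2c(c1)COC2=O` gives 7090 nM. In this assay compound 2 `Cc1cccc(NC(=O)Nc2ccc3c(c2)COC3=O)c1` gives 2260 nM, and compound 3 `Cc1ccc(NC(=O)Nc2ccc3c(c2)COC3=O)cc1` gives 2670 nM. Among these three numbers compound 3 has the second highest; between the two methyl compounds the step is a 1.2-fold higher number from compound 2 to compound 3 (0.07 log units; within the scatter), and the step from the unsubstituted compound is a 2.7-fold lower number from compound 1 to compound 3 (0.42 log units; beyond the scatter).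

Compound 4 `O=C(Nc1ccc(F)cc1)Nc1ccc2c(c1)COC2=O` differs from compound 3 in one place: fluoro in place of methyl on an aromatic carbon. For the measured compounds named here, no measured step introduces a fluoro anywhere in this set, so the bearing data are only the two methyl additions, a 3.1-fold lower number from compound 1 to compound 2 (0.50 log units; beyond the scatter) and a 2.7-fold lower number from compound 1 to compound 3 (0.42 log units; beyond the scatter). Taking the methyl away would be expected to undo the step from compound 1 to compound 3; what the fluoro gives back on its own is unknown here. The expected step is therefore a 1.7-fold higher number from compound 3 to compound 4 (0.23 log units; within the scatter), a modest rise toward compound 1 but with wide uncertainty. Compound 4 is estimated at 4500 nM in this assay, with a range from 2000 nM to 10000 nM.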

Compound 4, half-maximal inhibitory concentration: 4190 nM
For compound 4 the middle estimate is 1.1-fold (0.03 log units) above the measured one; the range from low to high includes it.
By their numbers in this assay, from the lowest: compounds 2, 3, 4 and 1 (each within the scatter of the next, the first and the last beyond it).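

In this assay the fluoro on this aromatic carbon cannot be told apart from the methyl, with a 1.6-fold higher number from compound 3 to compound 4 (0.20 log units; within the scatter) in this swap, nor from the hydrogen, with a 1.7-fold lower number from compound 1 to compound 4 (0.23 log units; within the scatter) in that one, so the new value falls within the scatter of both ends of a gap that the earlier compounds had shown to lie beyond it. The comparison with the 3-methylphenyl group reads the same way, with a 1.9-fold higher number from compound 2 to compound 4 (0.27 log units; within the scatter) on this exchange, so the fluoro does not separate from either methyl compound. The lower number that came with a methyl is therefore neither clearly kept nor clearly lost with a fluoro here, and nothing available explains this result.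

The compounds shown leave open whether a chloro, a methoxy, a trifluoromethyl, an amine or a carboxylic acid on this same aromatic carbon would move the number clearly beyond the scatter of compound 1. They also leave open whether a fluoro would read differently on the carbon that carries the methyl in the 3-methylphenyl group.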